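The source may hold more compounds than are shown below. What is called first, only, known or untested is meant among the compounds shown, and "the series" means these compounds.

Measured so far:
compound 1, `C/C(NNC(=S)N1CCc2cc(C(=O)O)ccc21)=C1/C(=O)N(c2ccc(C)c(C)c2)c2ccccc21`, with 138%;
compound 2, `C/C(NNC(=S)N1CCc2cc(C(=O)O)ccc21)=C1/C(=O)N(c2ccc(C)cc2)c2ccc(F)cc21`, with 122%.

Both were tested in an assay on BaF3 cells for inhibition of thrombopoietin receptor (Homo sapiens), tested at 300 nM; a higher number here means a stronger effect of the compound at the concentration tested, a lower number a weaker effect. Compound 2 stands lowest of the two numbers recorded; its nearest neighbour is compound 1, whose value lies higher by a margin beyond the usual scatter of such measurements. No pair of measured compounds differs in a single place, so no isolated step has been worked out from the data shown.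

Compound 3, `C/C(NNC(=S)N1CCc2cc(C(=O)O)ccc21)=C1/C(=O)N(c2ccc(C)cc2)c2ccccc21`, has not yet been measured in this assay. It is compound 2 with one change:

hydrogen in place of fluoro on an aromatic carbon

Going by the values given here, no measured pair shows what this particular change does, so the expectation for compound 3 rests only on the two values available and on the small size of the change. Compound 3 is expected to remain close to compound 2, with the step from compound 2 to compound 3, estimated as a number 6 percentage points higher from compound 2 to compound 3 (within the scatter), not clearly beyond the scatter of repeated measurements. On that basis compound 3 is estimated at 128%, with a likely range from 108% to 148%.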

Compound 3, a percentage reported as inhibition, at one concentration (the size of the read-out at that concentration, not a potency): 107%
Compound 3: middle estimate off by 21 percentage points, on the high side, outside the stated range (below it).
By their numbers in this assay, from the lowest: compound 3; then compound 2; then compound 1.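

In this assay the aromatic carbon of the six-membered aromatic ring of carbon only, part of a fused or bridged system of two rings, proves sensitive to a single atom, since hydrogen in place of fluoro there gives a number 15 percentage points lower from compound 2 to compound 3 (beyond the scatter) in the read-out. Going by these compounds alone, compound 3 also makes a second change readable for the first time, as the loss of one methyl group gives a number 31 percentage points lower from compound 1 to compound 3 (beyond the scatter) and is a large step, so the methyl group removed there also counts in this read-out. No measurement in hand accounts for either step.

As far as these compounds go, whether the step at the first carbon is particular to fluoro remains open, as chloro, methoxy or a nitrile at that carbon could each give a different read-out from those of compound 2 and compound 3. From the compounds shown here alone, it is equally open whether an ethyl group or a methoxy group in place of the methyl would hold the read-out of compound 1, and whether either step would keep its size with the other change in place.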